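The source may hold more compounds than are shown below. What is called first, only, known or untested is meant among the compounds shown, and "the series" means these compounds.

Values in a functional assay on DU-145 cells (Homo sapiens) for cytotoxicity, read by MTT assay, with a stated time of 48 h; a lower number here means a stronger inhibitor, a higher number a weaker inhibitor:
Compound 1, `COc1ccc(CN(C(=O)Nc2ccc(Cl)cc2)n2cnnc2)cc1OC`: 20400 nM
Compound 2, `COc1ccc(CN(C(=O)Nc2ccc(C#N)cc2)n2cnnc2)cc1OC`: 24100 nM
Compound 3, `Cc1ccsc1CN(C(=O)Nc1cccc(Cl)c1)n1cnnc1`: 20400 nM

Compound 1 and compound 2 share a core and differ by cyano in place of chloro on an aromatic carbon; the step of a 1.2-fold higher number from compound 1 to compound 2 (0.07 log units; within the scatter) is small. Compound 3 stands level with compound 1 at the digits given; the difference between the cores of compound 1 and compound 3 is not broken down here.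

Compound 4, `Cc1ccsc1CN(C(=O)Nc1cccc(C#N)c1)n1cnnc1`, has not been measured. It differs from compound 3 by cyano in place of chloro on an aromatic carbon. The surroundings are not identical to the earlier pair: in compound 1 to compound 2 the carbon is para to a large group, in compound 3 to compound 4 it is meta to a large group, so this is the same kind of change, not the same change.

Because the earlier step of a 1.2-fold higher number from compound 1 to compound 2 (0.07 log units; within the scatter) stayed within the scatter, compound 4 is expected to remain close to compound 3, an estimated step of a 1.2-fold higher number from compound 3 to compound 4 (0.07 log units; within the scatter). Compound 4 is estimated at 24000 nM, expected between 12000 nM and 50000 nM.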

Compound 4, half-maximal inhibitory concentration: 31000 nM
Beside the measured number, compound 4's estimate is 1.3-fold (0.11 log units) below it; measured number inside the range.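

In this assay, cyano in place of chloro on an aromatic carbon gives a 1.5-fold higher number from compound 3 to compound 4 (0.18 log units; within the scatter). The change carries from one core to the other without a difference that can be told from noise: the same change on two cores in this assay, a 1.2-fold higher number (0.07 log units; within the scatter) from compound 1 to compound 2 and a 1.5-fold higher number (0.18 log units; within the scatter) from compound 3 to compound 4, 1.3-fold (0.11 log units) apart, within the scatter of two such steps. For the compounds shown here, this does not show that the step would stay this small on other cores, and with only two pairs, which also differ in where the group sits on the ring, the effects of core and position cannot be separated.

Still open, from the compounds shown here alone, is whether a group other than chloro or cyano on this aromatic carbon, such as an amine or a carboxylic acid, would move the number beyond the scatter.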